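A few compounds are considered here, and "the series" means these few. Any claim that something is new, unique, unknown or untested is made for them only; others in the source may bear on it.

Compound 1, whose structure is `C#CCOC(=O)NN=C1C(Cl)=C(Cl)C(Cl)=C1Cl`, carries a propargyl group on an oxygen next to a carbonyl group, attached to a shared core. Its strength as an inhibitor was tested in a functional assay on MM1.S cells (Homo sapiens) for cytotoxicity, read by MTT assay, with a stated time of 48 h (a lower number here means a stronger inhibitor, a higher number a weaker inhibitor), yet for compound 1 the outcome is recorded only as "not determined" (no result reported), so no single number fixes where it stands. The one measured anchor in this small set is compound 2, with the structure `FC(F)(F)c1cccc(NN=C2C(Cl)=C(Cl)C(Cl)=C2Cl)c1`, which differs from compound 1 in more than one place; in this assay compound 2 gives 1000 nM. Compound 3, drawn as `CC(C)(C)OC(=O)NN=C1C(Cl)=C(Cl)C(Cl)=C1Cl`, is the compound still to be measured. It is reached from compound 1 by a single change: tert-butyl in place of propargyl on an oxygen next to a carbonyl group. Within the data shown here, with no measured pair showing what this change does, the expectation for the step from compound 1 to compound 3 in this assay is no shift beyond the usual scatter, in either direction. On that basis compound 3 is estimated to give 2000 nM, with a plausible range from 500 nM to 8000 nM.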

Compound 3, half-maximal inhibitory concentration: 600 nM
For compound 3 the middle estimate is 3.3-fold (0.52 log units) above the measured one; the range from low to high includes it.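

In this assay, among these compounds, compound 1 has the entry "not determined" (no result reported) and so no step to compound 3 can be read from these results. The compounds shown leave open what tert-butyl in place of propargyl does by itself to the strength of inhibition. Nothing else given here offers an explanation for the value of compound 3.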